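A Methoxycarbonyl Swap on a Weak Kinase Inhibitor

This account rests on a few compounds, and the source may have more. Where it says the series, first, only, none or still open, it means among the compounds named here.

Of the compounds shown here, two sharing the same amide-linked core have been measured in an assay on cells for inhibition of Rho-associated protein kinase 2 (Homo sapiens); a higher number here means a weaker inhibitor, a lower number a stronger inhibitor. Compound 1 `COc1cc(-c2cn[nH]c2)c(F)cc1NC(=O)C1COc2ccccc2C1` gives 6 nM. Compound 2 `Cc1ccc2c(c1)CC(C(=O)Nc1ccc(-c3cn[nH]c3)cc1)CO2` gives 4000 nM, the highest of the two numbers, and its gap to compound 1 lies beyond the scatter. The two compounds differ in several places at once, so their two values show only how far apart they stand, not which change is responsible. Compound 3 `COC(=O)c1ccc2c(c1)CC(C(=O)Nc1ccc(-c3cn[nH]c3)cc1)CO2` differs from compound 2 in one place: methoxycarbonyl in place of methyl on an aromatic carbon. Within the data shown here, no measured pair isolates this change, so there is no measured step to lean on. With the remainder of the molecule unchanged, a modest step is expected in this assay, with no firm direction. Compound 3 is therefore estimated at 3000 nM in this assay, in a range from 800 nM to 12000 nM, and the step this estimate implies is a 1.3-fold lower number from compound 2 to compound 3 (0.12 log units; within the scatter).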

Compound 3, half-maximal inhibitory concentration: 22 nM
Estimate against measurement, compound 3: 140-fold (2.13 log units) above, outside the stated range (below it).
By their numbers in this assay, from the lowest: compound 1; then compound 3; then compound 2.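

In this assay the swap on this aromatic carbon, meta to a fused ring and para to a fused ring, gives a 180-fold lower number from compound 2 to compound 3 (2.26 log units; beyond the scatter), so the number here depends strongly on the group at this position. Compound 1 and compound 2 differ in several places at once and could not tie any change to a single place, whereas this pair ties a large step to one substitution, in which methoxycarbonyl brings hydrogen-bond acceptors and a double bond that methyl lacks. No evidence here indicates which feature of the methoxycarbonyl group accounts for the step. The compounds shown leave open whether a carboxylic acid, a primary amide or a methoxy group on this carbon would give a similar number. They also leave open whether methoxycarbonyl would lower the number on the core of compound 1.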